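Swapping in an indole: what compound 4 might do

This account rests on a few compounds, and the source may have more. Where it says the series, first, only, none or still open, it means among the compounds named here.

Measured in a functional assay on SK-OV-3 cells (Homo sapiens) for cytotoxicity, read by spectrophotometry, with a stated time of 72 h; on this read-out higher numbers stand for weaker inhibition and lower numbers for stronger inhibition:
- compound 1 `COc1ccc(-c2cccc(=O)n2-c2cc(OC)c(OC)c(OC)c2)cc1O`: < 10 nM, a limit of the assay and not a number
- compound 2 `COc1cc(-n2c(-c3ccc([N+](=O)[O-])cc3)cccc2=O)cc(OC)c1OC`: 201 nM
- compound 3 `COc1ccc(-c2cccc(=O)n2-c2cc(OC)c(OC)c(OC)c2)cc1C`: 583 nM

Compound 3, at 583 nM, carries the highest number of the three and is the weakest inhibitor in this small set. The nearest number belongs to compound 2, and the gap is a 2.9-fold higher number from compound 2 to compound 3 (0.46 log units; beyond the scatter).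

Compound 4 `COc1cc(-n2c(-c3cccc4cc[nH]c34)cccc2=O)cc(OC)c1OC` has not yet been measured in this assay. It keeps the shared core and changes one group: 1H-indol-7-yl in place of 4-methoxy-3-methylphenyl on an aromatic carbon.

Going by the values given here, the closest precedent is another exchange of a whole group, a 2.9-fold higher number from compound 2 to compound 3 (0.46 log units; beyond the scatter), which was modest. Two steps involving compound 1 were large: an at least 20-fold higher number from compound 1 to compound 2 (1.30 log units; beyond the scatter) and an at least 58-fold higher number from compound 1 to compound 3 (1.76 log units; beyond the scatter). Among the compounds with values here, these show that changes to this group can matter a great deal, but no measured compound carries 1H-indol-7-yl, so the direction remains uncertain.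

Compound 3 already sits at the high end, so a modest move toward a lower number is expected, with a wide margin. The expected change is a 2.3-fold lower number from compound 3 to compound 4 (0.37 log units; beyond the scatter). For compound 4 the estimated value is 250 nM, with an expected range from 40 nM to 1500 nM.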

Compound 4, half-maximal inhibitory concentration: 138 nM
For compound 4 the middle estimate is 1.8-fold (0.26 log units) above the measured one; low and high end bracket the measured number.
By their numbers in this assay, from the lowest: compounds 4 and 2 (each within the scatter of the next); then compound 3. At a limit, below all of these: compound 1.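

In this assay, replacing a single aromatic ring with the two-ring 1H-indol-7-yl group, which brings one hydrogen-bond donor to this place, gives a 4.2-fold lower number from compound 3 to compound 4 (0.63 log units; beyond the scatter), while the exchange for 4-nitrophenyl gives a 1.5-fold lower number from compound 2 to compound 4 (0.16 log units; within the scatter), so two quite different groups cannot be told apart here. Neither group comes close to 3-hydroxy-4-methoxyphenyl, as the large step of an at least 13-fold higher number from compound 1 to compound 4 (1.13 log units; beyond the scatter) shows, and so the indole improves on 4-methoxy-3-methylphenyl without matching the best group in this set. Compound 1 stands at a limit of the assay and not at a number, so the true size of that step is unknown: the limit of < 10 nM in this assay, at which 1 of the 4 values shown sits.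

The compounds shown do not reveal whether the improvement over compound 3 goes with the hydrogen-bond donor of the indole, with its second ring, or with the loss of the methoxy and methyl groups. A naphthyl group, which has two rings and no such donor, and a 3-amino-4-methoxyphenyl group, which keeps the pattern of compound 1 with an amine in place of the hydroxy, would help to separate these possibilities.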